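This account rests on a few compounds, and the source may have more. Where it says the series, first, only, none or still open, it means among the compounds named here.

Measured compounds:
- compound 2 `COc1cccc(/C(C)=N/Nc2ncc(Cl)c(Nc3cccc(NC(=O)/C=C/CN(C)C)c3)n2)c1`: 3870 nM
- compound 1 `C=CC(=O)Nc1cccc(Nc2nc(N/N=C(\C)c3ccncc3)ncc2Cl)c1`: 12800 nM

In an ADME assay on HT-29 cells (Homo sapiens) for inhibition, read by MTT assay, with a stated time of 72 h (a higher number here means a weaker inhibitor, a lower number a stronger inhibitor), compound 2 gives 3870 nM, the lowest of the two numbers available. Among the measured compounds shown here, its nearest neighbour, compound 1, gives 12800 nM in this assay, a gap that lies beyond the usual scatter; the two compounds differ in more than one place, so no single step between them can be read.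

Compound 3 `C/C(=N\Nc1ncc(Cl)c(Nc2cccc(NC(=O)/C=C/CN(C)C)c2)n1)c1ccncc1` is the next compound to be measured. It differs from compound 2 by one change: pyridin-4-yl in place of 3-methoxyphenyl on a carbon with a double bond to nitrogen. For the measured compounds named here, no measured pair shows this change in isolation, so its effect is not known from the data. Compound 3 is expected to give 8000 nM in this assay, with a range of 3000 nM to 22000 nM. The expected step from compound 2 is a 2.1-fold higher number from compound 2 to compound 3 (0.32 log units; beyond the scatter), a rise beyond the scatter, though a result within the scatter of compound 2 would not be surprising.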

Compound 3, half-maximal inhibitory concentration: 10900 nM
For compound 3 the middle estimate is 1.4-fold (0.13 log units) below the measured one; the range from low to high includes it.
By their numbers in this assay, from the lowest: compound 2; then compounds 3 and 1 (each within the scatter of the next).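

In this assay, among the compounds shown here, pyridin-4-yl in place of 3-methoxyphenyl on a carbon with a double bond to nitrogen gives a 2.8-fold higher number from compound 2 to compound 3 (0.45 log units; beyond the scatter) as the first reading at this position, a modest step beyond the scatter. On the carbonyl carbon, 3-(dimethylamino)prop-1-en-1-yl in place of vinyl gives a 1.2-fold lower number from compound 1 to compound 3 (0.07 log units; within the scatter) with pyridin-4-yl held in both compounds, a step within the scatter. In these two pairs, then, only the change on the carbon with a double bond to nitrogen moves the number in this assay beyond the scatter.

From the compounds shown here alone, whether an unsubstituted phenyl, a pyridin-3-yl or a 4-methoxyphenyl group on that carbon would side with compound 2 or compound 3 stays open, as does how 3-methoxyphenyl behaves with vinyl on the carbonyl carbon. No measurement to hand accounts for either step.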